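Ring Closure of the Amino Substituent in a Thiazole Series

The source may report more compounds than this note shows. Statements on the series, on what has been measured and on what is new or still open speak of the compounds shown alone.

Compound 1 `CCN(CC)c1nc(N)c(C(=O)c2cc(OC)c(OC)c(OC)c2)s1` in a functional assay on HeLa cells (Homo sapiens) for antiproliferative activity, read by cell counting, with a stated time of 2 days; on this read-out lower numbers stand for stronger inhibition and higher numbers for weaker inhibition: 38000 nM
Compound 2 `CCCCN(C)c1nc(N)c(C(=O)c2cc(OC)c(OC)c(OC)c2)s1` in this assay: 31000 nM

Among the measured compounds shown here, compound 2 gives the lowest of the two numbers so far in this assay, yet its nearest neighbour, compound 1, sits only a step away that the data mark as within the scatter: a 1.2-fold lower number from compound 1 to compound 2 (0.09 log units; within the scatter). On that evidence the two compounds cannot be told apart, and nothing yet shows the amino substituent on the shared core to matter.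

Compound 3 `COc1cc(C(=O)c2sc(N3CCCCC3)nc2N)cc(OC)c1OC` carries the change (piperidin-1-yl in place of butyl(methyl)amino on an aromatic carbon). For the measured compounds named here, only one measured step bears on it, a 1.2-fold lower number from compound 1 to compound 2 (0.09 log units; within the scatter), which swaps one open-chain dialkylamino for another and stays within the scatter. Whether closing the substituent into a ring behaves differently is not shown by any measured pair. The expectation for compound 3 in this assay is therefore a step of a 1.0-fold lower number from compound 2 to compound 3 (0.01 log units; within the scatter), that is, none beyond the scatter. Compound 3 is estimated at 30000 nM, with a range from 12000 nM to 75000 nM.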

Compound 3, half-maximal inhibitory concentration: 11000 nM
Compound 3: the middle estimate sits 2.7-fold (0.44 log units) above what was measured, outside the stated range (below it).
By their numbers in this assay, from the lowest: compound 3; then compounds 2 and 1 (each within the scatter of the next).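

In this assay, the amino substituent on the shared core now makes a readable difference: piperidin-1-yl gives a 2.8-fold lower number from compound 2 to compound 3 (0.45 log units; beyond the scatter) and also a 3.5-fold lower number from compound 1 to compound 3 (0.54 log units; beyond the scatter), both modest but beyond the scatter, whereas the exchange between the two open-chain groups stayed within it. Butyl(methyl)amino and piperidin-1-yl match in their heavy atoms, carbon and nitrogen alike, so what separates compound 2 from compound 3 at this position on the five-membered aromatic ring is the six-membered non-aromatic ring itself. No measurement offered here accounts for the lower number that comes with the ring.

With compound 3 as the only ring-bearing member, the compounds shown cannot say whether the shift belongs to ring closure in general or to piperidin-1-yl in particular, and pyrrolidin-1-yl, azepan-1-yl or morpholin-4-yl at the same position would separate those readings. They also leave open whether a substituted ring such as 4-methylpiperidin-1-yl, or a simple unsubstituted amino group in place of the dialkylamino groups, would move the number further in either direction.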